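A few compounds are considered here, and "the series" means these few. Any claim that something is new, unique, unknown or untested is made for them only; others in the source may bear on it.

Measured so far in a functional assay on HeLa cells (Homo sapiens) for antiproliferative activity, read by MTT assay, with a stated time of 24 h; a lower number here means a stronger inhibitor, a higher number a weaker inhibitor:

compound 1 `CC1CCC(C(C)C)C(O[C@H]2OC(=O)C(Br)=C2Sc2nnc(-c3ccccc3O)s2)C1` gives 2900 nM
compound 2 `CC1CCC(C(C)C)C(O[C@H]2OC(=O)C(Br)=C2Sc2nnc(-c3ccc(O)cc3)s2)C1` gives 2600 nM

Compound 1 has the highest of the two numbers in this assay; its nearest neighbour is compound 2, and the step from one to the other, 4-hydroxyphenyl in place of 2-hydroxyphenyl on an aromatic carbon, is a 1.1-fold lower number from compound 1 to compound 2 (0.05 log units; within the scatter). The two hydroxyphenyl arrangements therefore cannot be told apart on these numbers.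

Compound 3 `CC1CCC(C(C)C)C(O[C@H]2OC(=O)C(Br)=C2Sc2nnc(-c3cccnc3)s2)C1` is not yet measured. It differs from compound 1 as follows: pyridin-3-yl in place of 2-hydroxyphenyl on an aromatic carbon. No measured step bears on a pyridin-3-yl at this position; the only step shown keeps the hydroxyphenyl and moves its hydroxy group, and that step stays within the scatter. With nothing in the series pointing either way, the expectation for compound 3 is a step of no change at the digits printed from compound 1 to compound 3 (within the scatter), that is, no change beyond the scatter. Compound 3 is accordingly estimated at 2900 nM, within a range of 1200 nM to 7000 nM.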

Compound 3, half-maximal inhibitory concentration: 5600 nM
Compound 3: middle estimate off by 1.9-fold (0.29 log units), on the low side; the measured number falls inside the stated range.
By their numbers in this assay, from the lowest: compounds 2, 1 and 3 (each within the scatter of the next, the first and the last beyond it).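

Changing the ring itself at this place on the shared core, rather than moving its hydroxy group, has a small effect in this assay: pyridin-3-yl in place of 2-hydroxyphenyl gives a 1.9-fold higher number from compound 1 to compound 3 (0.29 log units; within the scatter), and pyridin-3-yl in place of 4-hydroxyphenyl gives a 2.2-fold higher number from compound 2 to compound 3 (0.33 log units; beyond the scatter). Only the second step passes the scatter, and it is modest, so a ring with one hetero atom and no hydrogen-bond donor is accommodated here with at most a slight shift in the number. No measurement on hand accounts for this difference.

The hydroxy group and the ring nitrogen change together in these steps, so their separate contributions remain unresolved. Unsubstituted phenyl, aminophenyl or carboxyphenyl at this place would show how far the series holds beyond these three rings.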